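Two triazole analogues, both at the assay ceiling

The source may hold more compounds than are shown below. What is called first, only, known or untested is meant among the compounds shown, and "the series" means these compounds.

Measured so far:
- compound 1 `C=C1C[C@]23C[C@@]1(O)CC[C@H]2c1ccc(OS(=O)(=O)c2ccc(C)cc2)c(C)c1[C@@H]3Cn1cc(-c2ccc(Br)cc2)nn1`: > 20000 nM
- compound 2 `C=C1C[C@]23C[C@@]1(O)CC[C@H]2c1cc(Br)c(O)c(C)c1[C@@H]3Cn1cc(-c2ccc(OC)cc2)nn1`: > 20000 nM

Both readings come from a functional assay on SMMC-7721 cells (Homo sapiens) for cytotoxicity, read by MTT assay, with a stated time of 4 days; a higher number here means a weaker inhibitor, a lower number a stronger inhibitor. For compound 1 the figure given is a limit of the assay, not a number. For compound 2 the figure is likewise a limit and not a number. For the measured compounds named here, compound 2 therefore stands at the limit of > 20000 nM in this assay, at which 2 of the 2 values shown sit, so nothing separates it from the one other compound recorded, and no measured step exists between any pair.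

Compound 3 `C=C1C[C@]23C[C@@]1(O)CC[C@H]2c1cc(Br)c(O)c(C)c1[C@@H]3Cn1cc(-c2ccc(Cl)cc2)nn1` differs from compound 2 in one place: chloro in place of methoxy on an aromatic carbon. With both known values sitting as limits, no size of step can be read from the data, and none beyond the scatter is expected here. Compound 3 is accordingly estimated at 30000 nM, within a range of 8000 nM to 120000 nM. That estimate implies a step that the limit leaves unreadable from compound 2 to compound 3, and most likely only a limit will again be reported.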

Compound 3, half-maximal inhibitory concentration: 19100 nM
Compound 3: middle estimate off by 1.6-fold (0.20 log units), on the high side; low and high end bracket the measured number.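

In this assay, for the compounds shown here, compound 3 gives the first reading in this set that is a number and not a limit, 19100 nM. Putting chloro in place of methoxy, which turns 4-methoxyphenyl into 4-chlorophenyl, gives an at least 1.0-fold lower number from compound 2 to compound 3 (0.01 log units; that floor lies within the scatter), so the change has a floor but no measured size, and the data show no change at this position beyond the scatter. The figure for compound 2 remains a limit of the assay and not a number: the limit of > 20000 nM in this assay, at which 2 of the 3 values shown sit.

Going by these compounds, it remains open how far the true value of compound 2 lies from that limit, and so how large the step really is. On these data alone, it also remains open how an amine or a carboxylic acid in place of the chloro on that aromatic carbon would read in this assay.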